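The compounds below may be only part of what the source reports. "The series", "measured", "known", "first", "only" and "open" are said of these compounds alone.

Working notes on the series. Compound 1 `COc1ccc(C2=C(c3cc(OC)c(OC)c(OC)c3)C(=O)C(OC(C)=O)C2)cc1` and compound 2 `COc1ccc(C2=C(c3cc(OC)c(OC)c(OC)c3)C(=O)C(OC(C)=O)C2)cc1F` differ only by fluoro in place of hydrogen on an aromatic carbon. In an ADME assay on L132 cells (Homo sapiens) for cytotoxicity, read by MTT assay, with a stated time of 72 h (on this read-out higher numbers stand for weaker inhibition and lower numbers for stronger inhibition), compound 1 gives > 100 ug/mL, which is a limit of the assay. Compound 2 gives < 1 ug/mL, also a limit, so its position is known only as a limit and no exact number is available. Among the measured compounds shown here, the sole measured step is large and beyond the scatter: an at least 100-fold lower number from compound 1 to compound 2 (2.00 log units; beyond the scatter).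

Compound 3 `COc1ccc(C2=C(c3cc(OC)c(OC)c(OC)c3)C(=O)C(OC(C)=O)C2)cc1Cl` carries chloro in place of fluoro on the same aromatic carbon, ortho to a methoxy group and meta to a large group: chloro in place of fluoro on an aromatic carbon. For the measured compounds named here, no measured step covers this exchange directly. The nearest evidence is an at least 100-fold lower number from compound 1 to compound 2 (2.00 log units; beyond the scatter), which introduced the fluoro now being replaced. Since compound 3 also keeps a halogen on that carbon, no step beyond the scatter is expected in this assay, and no direction is favoured. The estimated step is a step that the limit leaves unreadable from compound 2 to compound 3. In this assay the estimate for compound 3 is 0.8 ug/mL, with an expected range from 0.1 ug/mL to 8 ug/mL.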

Compound 3, half-maximal inhibitory concentration: < 1 ug/mL
Compound 3: only a limit was reported; the forecaster's own chance of this, stated with the estimate: 55%; the middle value is on the limit's open side.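

The large change at this aromatic carbon, ortho to a methoxy group, is not tied to fluoro alone: with chloro in place of hydrogen, this assay shows an at least 100-fold lower number from compound 1 to compound 3 (2.00 log units; beyond the scatter). Compound 3 is reported only as a limit, < 1 ug/mL. The step from fluoro to chloro cannot be read, and no order of the two halogens follows from these data, because both values stand at the same limit: the limit of < 1 ug/mL in this assay, at which 2 of the 3 values shown sit.

Going by these compounds, how far past that limit either halogen compound lies stays open, as does the true position of the hydrogen compound, which also stands at a limit: the limit of > 100 ug/mL in this assay, at which 1 of the 3 values shown sits. Also open is whether a group other than a halogen on the same carbon, such as an amine, a methyl group or a nitrile, would give a step of this kind, or whether the halogens are alone in doing so among groups at this position.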